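Series notes: from pyridin-3-yl to pyridin-4-yl

A few compounds are considered here, and "the series" means these few. Any claim that something is new, unique, unknown or untested is made for them only; others in the source may bear on it.

Values measured in an ADME assay on Vero cells (Chlorocebus sabaeus) for cytotoxicity, read by luminescence, with a stated time of 2 days (a higher number here means that more compound is tolerated, a lower number that less compound is tolerated), are as follows.
Compound 1 (`CCc1nc2ccccc2n1CCCCOc1ccc(Cl)cc1Cl`) gives 23 uM
Compound 2 (`CCc1nc2ccccc2n1CCCCOc1ccc(Cl)c(F)c1`) gives 16 uM
Compound 3 (`CCc1nc2ccccc2n1CCCCOc1cccnc1`) gives > 50 uM

For compound 3 the reading (> 50 uM) is a limit of the assay and not a number. The next structure is compound 4 (`CCc1nc2ccccc2n1CCCCOc1ccncc1`), which has the same atoms as compound 3, joined differently: pyridin-4-yl in place of pyridin-3-yl on an oxygen on a saturated carbon. In words, pyridin-4-yl stands in place of pyridin-3-yl on an oxygen on a saturated carbon.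

Two measured steps at this place bear on the change: an at least 2.1-fold higher number from compound 1 to compound 3 (0.33 log units; beyond the scatter) and an at least 3.1-fold higher number from compound 2 to compound 3 (0.49 log units; beyond the scatter). Both bring in pyridin-3-yl in place of a substituted phenyl group. The exchange of one such phenyl group for the other gave a 1.4-fold lower number from compound 1 to compound 2 (0.16 log units; within the scatter). Going by the values given here, no measured step exchanges one pyridinyl group for another. Since a pyridinyl group stays in place, no step beyond the scatter is expected in this assay, and a second reading at the limit is quite likely. Any numeric reading would have to fall on the lower side of that limit. The expected step is an at least 1.1-fold lower number from compound 3 to compound 4 (0.04 log units; that floor lies within the scatter). For compound 4 the estimate is 45 uM, with an expected range from 22 uM to 80 uM.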

Compound 4, half-maximal toxic concentration: > 50 uM
Compound 4: no number, only a limit (the forecaster's own chance of this, stated with the estimate: 55%); middle value at least 1.1-fold (0.04 log units) away from the limit.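

In this assay compound 4 gives > 50 uM, which is a limit of the assay and not a number. With pyridin-4-yl on the oxygen, the reading again clears both substituted phenyl compounds, with an at least 3.1-fold higher number from compound 2 to compound 4 (0.49 log units; beyond the scatter) and an at least 2.1-fold higher number from compound 1 to compound 4 (0.33 log units; beyond the scatter), so among the compounds shown the higher reading is no longer tied to pyridin-3-yl alone. The direct exchange of one pyridinyl group for the other cannot be read, because compound 3 and compound 4 both stand at the same ceiling: the limit of > 50 uM in this assay, at which 2 of the 4 values shown sit.

Still open, on these data alone, is whether pyridin-2-yl or a pyrimidinyl group on the same oxygen would also reach that limit, and whether an unsubstituted phenyl group would read with the pyridinyl compounds or with the halogenated phenyl compounds 1 and 2. Also open, as far as these compounds go, is whether the pyridinyl compounds would keep these readings with a longer chain in place of the saturated chain that carries the oxygen.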